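The source may hold more compounds than are shown below. What is called first, only, known or untested is meant among the compounds shown, and "the series" means these compounds.

Measured so far:
- compound 1, `COc1ccc(C(=O)c2ccc3c(ccn3S(=O)(=O)c3ccc(/C=C/C(=O)NO)cc3)c2)cc1`; in an assay on isolated protein for inhibition of histone deacetylase 8 (Homo sapiens) (a lower number here means a stronger inhibitor, a higher number a weaker inhibitor), compound 1 gives 10000 nM.
- compound 2, `O=C(NO)c1ccc(Cn2ccc3cc(C(=O)c4ccc(F)cc4)ccc32)cc1`; in this assay compound 2 gives 1240 nM.
- compound 3, `COc1cccc(C(=O)c2ccc3c(ccn3S(=O)(=O)c3cccc(/C=C/C(=O)NO)c3)c2)c1`; in this assay compound 3 gives 3530 nM.

Compound 2 holds the lowest number of the three. Compound 3 stands above it by a gap beyond the scatter, and compound 1 further above still, so compound 2 is the strongest inhibitor of the three shown. The two benzenesulfonyl compounds, compound 1 and compound 3, are the weaker pair, with compound 1 the weaker of the two.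

Compound 4, `O=C(NO)c1ccc(Cn2ccc3cc(C(=O)c4ccc(Cl)cc4)ccc32)cc1`, is not yet measured in this assay. It differs from compound 2 by chloro in place of fluoro on an aromatic carbon. No measured pair in this series carries that change, so its size cannot be read from the numbers shown. The expectation is a step that stays within the scatter, with no clear direction. The estimated value for compound 4 in this assay is 1100 nM, within 500 nM to 2500 nM. The expected step from compound 2 to compound 4 is a 1.1-fold lower number from compound 2 to compound 4 (0.05 log units; within the scatter).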

Compound 4, half-maximal inhibitory concentration: 1060 nM
Beside the measured number, compound 4's estimate is 1.0-fold (0.02 log units) above it; the range from low to high includes it.
By their numbers in this assay, from the lowest: compounds 4 and 2 (each within the scatter of the next); then compound 3; then compound 1.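

In this assay, going by these compounds alone, chloro in place of fluoro on an aromatic carbon, para to a large group, gives a 1.2-fold lower number from compound 2 to compound 4 (0.07 log units; within the scatter), the first reading of any single change. At this position, the 4-fluorophenyl and 4-chlorophenyl groups therefore cannot be told apart, and this one pair shows that the position accepts either halogen without a step beyond the scatter. Nothing available bears on why the two compounds read alike.

On these data alone, whether a trifluoromethyl, an amine or a carboxylic acid at this position would give a step beyond the scatter stays open. Compound 1 and compound 3 differ from compound 2 and compound 4 in more than one place, so steps to them cannot be read.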